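This account rests on a few compounds, and the source may have more. Where it says the series, first, only, none or still open, it means among the compounds named here.

In a functional assay on K562 cells (Homo sapiens) for inhibition (a lower number here means a stronger inhibitor, a higher number a weaker inhibitor), three compounds sharing a core have been measured: compound 1 `CC(C)CC(=O)OC1C(C(O)CO)OC2OC(C)(C)OC21` gives 1000000 nM, compound 2 `CC1(C)OC2OC(C(O)CO)C(OC(=O)C(C)(C)C)C2O1` gives 1500000 nM, and compound 3 `CC(C)(C)CC(=O)OC1C(C(O)CO)OC2OC(C)(C)OC21` gives 1200000 nM. Compound 3 thus stands within the scatter of both others. Compound 4 `CCCCC(=O)OC1C(C(O)CO)OC2OC(C)(C)OC21` is still unmeasured; it differs from compound 3 as follows: propyl in place of tert-butyl on a saturated chain carbon bound to a carbonyl carbon. The same difference reads neopentyl to butyl. The measured changes to the group on the carbonyl carbon bear on this: a 1.5-fold higher number from compound 1 to compound 2 (0.18 log units; within the scatter), a 1.2-fold higher number from compound 1 to compound 3 (0.08 log units; within the scatter) and a 1.3-fold lower number from compound 2 to compound 3 (0.10 log units; within the scatter), each within the scatter. For the measured compounds named here, none of the measured compounds carries butyl, so this remains an extrapolation. No step beyond the scatter is expected in this assay. The expected step is no change at the digits printed from compound 3 to compound 4 (within the scatter). The estimate for compound 4 is 1200000 nM, with an expected range from 700000 nM to 2000000 nM.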

Compound 4, half-maximal inhibitory concentration: 2000000 nM
For compound 4 the middle estimate is 1.7-fold (0.22 log units) below the measured one; the measured number falls inside the stated range.
By their numbers in this assay, from the lowest: compounds 1, 3, 2 and 4 (each within the scatter of the next).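

In this assay, for the compounds shown here, the butyl of compound 4, the first group on the carbonyl carbon without a branch, gives a 1.7-fold higher number from compound 3 to compound 4 (0.22 log units; within the scatter) and a 1.3-fold higher number from compound 2 to compound 4 (0.12 log units; within the scatter) and also a 2.0-fold higher number from compound 1 to compound 4 (0.30 log units; within the scatter) against the branched groups. Across these four compounds, then, the swap from a branched to a straight chain at this position produces no step beyond the scatter.

As far as these compounds go, whether an amine, a carboxylic acid or a chain longer than butyl on the carbonyl carbon would shift the number beyond the scatter stays open. Nothing available here accounts for these numbers.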